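Solubility notes: fluorophenyl isomer of compound 2

The compounds below may be only part of what the source reports. "The series", "measured", "known", "first", "only" and "open" are said of these compounds alone.

The series shares one core, seen in compound 1 `Cc1cc(NC(=O)Nc2ccc(N)cc2)c2ccccc2n1` and compound 2 `Cc1cc(NC(=O)Nc2ccccc2F)c2ccccc2n1`, each carrying a phenyl group on the amide-type nitrogen. Among the measured compounds shown here, in a physicochemical assay for solubility, at pH 7.4 (a lower number here means a less soluble compound, a higher number a more soluble compound), compound 1 gives 18500 nM, and compound 2 gives 3800 nM, the lowest of the two numbers measured so far. For the measured compounds named here, the single measured step is a 4.9-fold lower number from compound 1 to compound 2 (0.69 log units; beyond the scatter). Compound 3 `Cc1cc(NC(=O)Nc2ccc(F)cc2)c2ccccc2n1` differs from compound 2 by 4-fluorophenyl in place of 2-fluorophenyl on an amide-type nitrogen. Going by the values given here, no measured pair exchanges one fluorophenyl for another, so that step bears only indirectly: it shows the phenyl substituent can move the number, not what this exchange does. With the same atoms joined differently, there is no ground to expect a step beyond the scatter in this assay. The step of a 1.3-fold lower number from compound 2 to compound 3 (0.10 log units; within the scatter) is expected to stay within the scatter. The estimate for compound 3 in this assay is 3000 nM, in the range 1200 nM to 9000 nM.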

Compound 3, solubility: 3700 nM
Estimate against measurement, compound 3: 1.2-fold (0.09 log units) below, within the range that was stated.
By their numbers in this assay, from the lowest: compounds 3 and 2 (each within the scatter of the next); then compound 1.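

In this assay, 4-fluorophenyl in place of 2-fluorophenyl on the amide-type nitrogen gives a 1.0-fold lower number from compound 2 to compound 3 (0.01 log units; within the scatter) and so separates the two isomers by nothing beyond the scatter, something the earlier pair could not show because it differed in both the substituent and its place. With the place held, fluoro in place of amino on an aromatic carbon gives a 5.0-fold lower number from compound 1 to compound 3 (0.70 log units; beyond the scatter) and isolates the substituent exchange, so for these compounds the number tracks which group is present and not where the fluorine stands. No measurement on hand gives a reason for either step.

On these data alone, whether the place of the substituent stays without consequence for a carboxylic acid or a trifluoromethyl group on the phenyl ring remains open. As far as these compounds go, a morpholine in place of the fluoro is equally open.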